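Chloro Substitution on a Thiazolyl Ketone Series

A few compounds are considered here, and "the series" means these few. Any claim that something is new, unique, unknown or untested is made for them only; others in the source may bear on it.

Measured compounds:
compound 1 `Cc1nc(-c2ccc(Cl)cc2)sc1C(=O)CSc1nc(-c2ccccc2)c(C#N)c(=O)[nH]1` — 83.1%
compound 2 `Cc1nc(-c2ccc(Cl)cc2)sc1C(=O)CSc1nc(-c2cccc(Cl)c2)c(C#N)c(=O)[nH]1` — 95.2%
compound 3 `Cc1nc(-c2ccccc2)sc1C(=O)CSc1nc(N)c(C#N)c(-c2ccc(Cl)cc2)n1` — 58.8%

In a functional assay on U-87MG ATCC cells for antiproliferative activity against U-87 MG (Homo sapiens), read by MTT assay, with a stated time of 48 h, tested at 10 uM (on this read-out higher numbers stand for a weaker effect at the one concentration tested and lower numbers for a stronger effect), compound 1 gives 83.1% and compound 2 gives 95.2%. The two differ by chloro in place of hydrogen on an aromatic carbon, and the step is a number 12.1 percentage points higher from compound 1 to compound 2 (beyond the scatter). Compound 3 gives 58.8% in this assay, the lowest of the three; the difference between its core and that of compound 1 is not broken down here. Compound 4 `Cc1nc(-c2ccc(Cl)cc2)sc1C(=O)CSc1nc(N)c(C#N)c(-c2ccc(Cl)cc2)n1` has not yet been measured. It differs from compound 3 by chloro in place of hydrogen on an aromatic carbon, the same kind of change as from compound 1 to compound 2, but the place is not the same: there the chloro sits meta to a large group, here para to a large group. Resting on the single earlier step, the step from compound 3 to compound 4 in this assay is expected to be a number 9.2 percentage points higher from compound 3 to compound 4 (within the scatter), so compound 4 is estimated at 68%, between 52% and 85%.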

Compound 4, a percentage reported as activity, at one concentration (the size of the read-out at that concentration, not a potency): 37.3%
For compound 4 the middle estimate is 30.7 percentage points above the measured one; measured number outside the range, below it.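

In this assay, the chloro change gives a number 21.5 percentage points lower from compound 3 to compound 4 (beyond the scatter), so on this core the 4-chlorophenyl group goes with the stronger effect at the one concentration tested. Set beside the earlier step, the same kind of change does not carry over from one core to the other: the same change on two cores in this assay, a number 12.1 percentage points higher (beyond the scatter) from compound 1 to compound 2 and a number 21.5 percentage points lower (beyond the scatter) from compound 3 to compound 4, 33.6 percentage points apart, beyond the scatter of two such steps This does not show whether the core or the place of the chloro decides the outcome, since the two pairs differ in both and each is a single pair.

The compounds shown leave open whether a chloro at one place would act alike on both cores. They also leave open whether a fluoro or methoxy group at that place would follow the chloro.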